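Hydroxyalkyl capping of the pyrazole nitrogen in compound 1

This account rests on a few compounds, and the source may have more. Where it says the series, first, only, none or still open, it means among the compounds named here.

Measured compounds:
compound 1 `Cc1cc(Nc2nc(NCc3ccc(F)cc3F)nc3[nH]ncc23)n[nH]1`: 96.1 nM
compound 2 `Cc1cc(Nc2nc(NCc3ccc(F)c(F)c3)nc3[nH]ncc23)n[nH]1`: entry "nd" (no result reported)
compound 3 `Cc1cc(Nc2nc(NCc3ccc(C#N)cc3)nc3[nH]ncc23)n[nH]1`: entry "nd" (no result reported)

Among the compounds with values here, in an assay on isolated protein for inhibition of serine/threonine-protein kinase PAK 4 (Homo sapiens), read by HTRF, with a stated time of 60 min (on this read-out higher numbers stand for weaker inhibition and lower numbers for stronger inhibition), compound 1 gives 96.1 nM, the only number in this set; for compound 2 and compound 3 no result was reported, so compound 1 stands alone without comparison. Compound 4 `Cc1cc(Nc2nc(NCc3ccc(F)cc3F)nc3c2cnn3CC(C)(C)O)n[nH]1` differs from it in one place: 2-hydroxy-2-methylpropyl in place of hydrogen on an aromatic nitrogen, so the aromatic nitrogen of the shared core carries a 2-hydroxy-2-methylpropyl chain instead of a hydrogen. Within the data shown here, no step between measured compounds speaks to such a change, so no direction can be drawn from the data. The step from compound 1 to compound 4 is expected to be a 1.4-fold lower number from compound 1 to compound 4 (0.14 log units; within the scatter), not beyond the scatter. Compound 4 is estimated at 70 nM, between 18 nM and 280 nM.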

Compound 4, half-maximal inhibitory concentration: 655 nM
For compound 4 the middle estimate is 9.4-fold (0.97 log units) below the measured one, and the stated range ends below it.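

In this assay, the aromatic nitrogen of the shared core does not accept this change without cost: 2-hydroxy-2-methylpropyl in place of hydrogen gives a 6.8-fold higher number from compound 1 to compound 4 (0.83 log units; beyond the scatter), which means weaker inhibition. Within the data shown here, this is the only measured step at this position, so it speaks for this one chain alone. No available measurement accounts for the loss. The compounds shown leave open how a methyl group, a chain ending in an amine or a chain ending in a carboxylic acid would fare on this nitrogen.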